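Swapping nitro for methyl on the benzyl group of compound 2

A few compounds are considered here, and "the series" means these few. Any claim that something is new, unique, unknown or untested is made for them only; others in the source may bear on it.

The set comprises three measured oxime ethers and one yet to be tested. Compound 2 `Cc1ccc(-c2nc3ccc(Br)cn3c2/C=N/OCc2cn(Cc3ccc([N+](=O)[O-])cc3)nn2)cc1` gives the lowest number of the three in a functional assay on the whole organism (strain NMRI) with Mus musculus as the target, with a stated time of 4 h (a lower number here means that less compound is needed, a higher number that more compound is needed for the effect), with a minimum effective dose of 20 mg/kg. Compound 3 `O=[N+]([O-])c1ccc(Cn2cc(CO/N=C/c3c(-c4ccccc4)nc4ccc(Br)cn34)nn2)cc1` is its nearest neighbour. In this assay compound 3 gives 40 mg/kg, and the step of a 2.0-fold higher number from compound 2 to compound 3 (0.30 log units; within the scatter) concerns the loss of a methyl from an aromatic carbon. Compound 1 `COc1ccc(Cn2cc(CO/N=C/c3c(-c4ccc(C)cc4)nc4c(C)cccn34)nn2)cc1` lies furthest away, with 100 mg/kg, but it differs from compound 2 in more than one place, so its gap cannot be assigned to any single change.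

Compound 4 `Cc1ccc(Cn2cc(CO/N=C/c3c(-c4ccc(C)cc4)nc4ccc(Br)cn34)nn2)cc1` differs from compound 2 in one place: methyl in place of nitro on an aromatic carbon. Within the data shown here, no measured pair covers this exchange, and the only single-site step known, from compound 2 to compound 3, touches a different ring and stays within the scatter. Nothing in the data therefore argues for a shift beyond the scatter in either direction. Compound 4 is accordingly expected to give about 30 mg/kg in this assay, within a range of 10 mg/kg to 100 mg/kg, which amounts to an estimated step of a 1.5-fold higher number from compound 2 to compound 4 (0.18 log units; within the scatter).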

Compound 4, minimum effective dose: 100 mg/kg
For compound 4 the middle estimate is 3.3-fold (0.52 log units) below the measured one, and the stated range covers the measured number.
By their numbers in this assay, from the lowest: compounds 2 and 3 (each within the scatter of the next); then compounds 1 and 4 (each within the scatter of the next).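

In this assay, among these compounds, the exchange of 4-nitrobenzyl for 4-methylbenzyl gives a 5.0-fold higher number from compound 2 to compound 4 (0.70 log units; beyond the scatter), the only single-site step in this set that goes beyond the scatter. Among the compounds shown here, the position para to the large group on the benzyl ring is therefore sensitive to this change, whereas the one earlier single-site step, on a different ring, did not leave the scatter. No measurement available here accounts for the loss on going from nitro to methyl.

From the compounds shown here alone, with only these two groups compared at this position, it remains open whether a nitrile, a trifluoromethyl group, an amine or plain hydrogen would track compound 2 or compound 4. Going by these compounds, it is also open whether the exchange would have a similar effect with the unsubstituted phenyl of compound 3.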